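The source may hold more compounds than are shown below. What is called first, only, known or untested is meant among the compounds shown, and "the series" means these compounds.

Measured compounds:
compound 1 `CCCn1c(=O)[nH]c2nc(-c3ccc(S(=O)(=O)N4CCN(c5ccccc5)CC4)cc3)[nH]c2c1=O` — 364 nM
compound 2 `CCCn1c(=O)[nH]c2nc(-c3ccc(S(=O)(=O)N4CCN(Cc5cccc(Br)c5)CC4)cc3)[nH]c2c1=O` — 928 nM
compound 3 `CCCn1c(=O)[nH]c2nc(-c3ccc(S(=O)(=O)N4CCN(Cc5cccc(C)c5)CC4)cc3)[nH]c2c1=O` — 795 nM

All three were run in an assay on CHO cells for displacement of a labelled ligand from adenosine receptor A1 (Homo sapiens), read by scintillation counting, with a stated time of 90 min, in the presence of a further agent that is not named here; a lower number here means a stronger inhibitor, a higher number a weaker inhibitor. Compound 1 holds the lowest number of the three. The two others sit above it by steps that clear the scatter: a 2.5-fold higher number from compound 1 to compound 2 (0.41 log units; beyond the scatter) and a 2.2-fold higher number from compound 1 to compound 3 (0.34 log units; beyond the scatter). Between the two others there is nothing to separate, a 1.2-fold lower number from compound 2 to compound 3 (0.07 log units; within the scatter), so the two substituents on the aromatic carbon do not set the two apart.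

Compound 4 `CCCn1c(=O)[nH]c2nc(-c3ccc(S(=O)(=O)N4CCN(C(C)c5ccccc5)CC4)cc3)[nH]c2c1=O` is the next case. It differs from compound 1 in one place: 1-phenylethyl in place of phenyl on an amine nitrogen in a ring. Among the compounds with values here, the steps that bear on it are the two already seen from compound 1, where phenyl on the amine nitrogen in the ring was also replaced by a larger group carrying its own aromatic ring, and each time the number rose modestly but beyond the scatter. Neither of those groups is the one entering here, so the comparison is indirect; still, both point the same way. Compound 4 is therefore expected to give a modestly higher number than compound 1, a 2.1-fold higher number from compound 1 to compound 4 (0.31 log units; beyond the scatter). The estimate for compound 4 is 750 nM, with a likely range from 350 nM to 1600 nM.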

Compound 4, inhibition constant: >= 1000 nM
Compound 4: a limit, no number; the forecaster's own chance of this, stated with the estimate: 3%; middle value at least 1.3-fold (0.12 log units) away from the limit.
By their numbers in this assay, from the lowest: compound 1; then compounds 3 and 2 (each within the scatter of the next). At a limit, above all of these: compound 4.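

Compound 4 is reported in this assay only as a limit, >= 1000 nM, and not as a number: the limit of >= 1000 nM in this assay, at which 1 of the 4 values shown sits. With 1-phenylethyl on the amine nitrogen in the ring there is an at least 2.7-fold higher number from compound 1 to compound 4 (0.43 log units; beyond the scatter), so all three groups shown in place of phenyl at this position give a higher number than compound 1, and none of the compounds shown goes against this. The limit does not place 1-phenylethyl relative to the two substituted benzyl groups, with an at least 1.2-fold higher number from compound 3 to compound 4 (0.09 log units; that floor lies within the scatter) and an at least 1.0-fold higher number from compound 2 to compound 4 (0.03 log units; that floor lies within the scatter), so neither step gives an order.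

Going by these compounds, how far the true value of compound 4 lies past the limit remains open, and so does the size of the step from phenyl to 1-phenylethyl beyond its floor. The compounds shown also leave open whether unsubstituted benzyl, a small alkyl group such as methyl, or a phenyl ring carrying a methoxy group or a carboxylic acid on the amine nitrogen in the ring would match or lower the number of compound 1.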